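Swapping the halophenyl of compound 3 for a chloropyridine

A few compounds are considered here, and "the series" means these few. Any claim that something is new, unique, unknown or untested is made for them only; others in the source may bear on it.

Compound 1 `CN(Cc1cc(-c2ccccc2Cl)no1)C(=O)C1CCNCC1` gives 350 nM in an assay on isolated protein for positive allosteric modulation of Neuronal acetylcholine receptor; alpha4/beta2 (Homo sapiens); on this read-out higher numbers stand for an effect only at larger amounts of compound and lower numbers for an effect already at smaller amounts.
Compound 2 `Cc1c(-c2cc(-c3c(F)cccc3Cl)no2)cnn1C1CCNCC1` gives 6 nM in this assay.
Compound 3 `Fc1ccc(Cl)c(-c2cc(-c3cnn(C4CCNCC4)c3)on2)c1` gives 270 nM in this assay.

Among the three measured compounds, compound 3 has the second highest number in this assay. Its nearest neighbour is compound 1, whose number lies within the usual scatter of that of compound 3, so the two cannot be told apart. Compound 2 is furthest away, with a number well below that of compound 3 and clearly beyond the scatter. Going by the values given here, no pair of measured compounds differs in a single place, so no measured step guides the next change.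

Compound 4 `Clc1cnccc1-c1cc(-c2cnn(C3CCNCC3)c2)on1` differs from compound 3 in one place: 3-chloropyridin-4-yl in place of 2-chloro-5-fluorophenyl on an aromatic carbon. No comparable exchange has been measured in this set. A modest step is expected in this assay, most likely towards a somewhat higher number, though a result within the scatter would not surprise. For compound 4 the estimate is 500 nM with a range from 120 nM to 2500 nM. The expected step from compound 3 to compound 4 is a 1.9-fold higher number from compound 3 to compound 4 (0.27 log units; within the scatter).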

Compound 4, half-maximal effective concentration: 200 nM
Estimate against measurement, compound 4: 2.5-fold (0.40 log units) above; measured number inside the range.
By their numbers in this assay, from the lowest: compound 2; then compounds 4, 3 and 1 (each within the scatter of the next).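

In this assay the exchange of 2-chloro-5-fluorophenyl for 3-chloropyridin-4-yl gives a 1.4-fold lower number from compound 3 to compound 4 (0.13 log units; within the scatter) and so leaves the two compounds indistinguishable. Going by these compounds alone, this is the first single-place comparison in the set, and it shows that this position, on an aromatic carbon next to the ring nitrogen, accepts a six-membered aromatic ring with 1 hetero atom and one hydrogen-bond acceptor in place of a ring of carbon only, with the fluorine gone, and no change beyond the scatter. No measurement shown here offers an explanation for this result.

As far as these compounds go, whether the chlorine itself matters remains open, since a methoxy group or an amine in its place could test that. From the compounds shown here alone, it is also open whether a pyrimidine ring in place of the pyridine would leave the number in this assay within the scatter.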